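A few compounds are considered here, and "the series" means these few. Any claim that something is new, unique, unknown or untested is made for them only; others in the source may bear on it.

Measured so far:
- Compound 1, `COc1ccc(Nc2nnnn2-c2cccc(Br)c2)cc1`: 124000 nM
- Compound 2, `COc1ccc(-n2nnnc2Nc2ccc(Br)cc2)cc1`: 212000 nM
- Compound 3, `COc1ccc(-n2nnnc2Nc2ccc(F)cc2)cc1`: 236000 nM

All three numbers come from an ADME assay on V79 cells (Cricetulus griseus) for cytotoxicity, read by MTT assay, with a stated time of 72 h; a lower number here means a stronger inhibitor, a higher number a weaker inhibitor. Compound 1 gives the lowest of the three, yet its distance to compound 2 and to compound 3 stays within the usual scatter, so no order among them can be claimed. Compound 2 and compound 3 differ only in a halogen, and that step, a 1.1-fold higher number from compound 2 to compound 3 (0.05 log units; within the scatter), is likewise within the scatter; the swap of one halogen for another left the read-out essentially unchanged. Compound 1 differs from compound 2 in two places at once, so their two values show only that they lie close together.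

The next compound, compound 4, is `COc1ccc(Nc2nnnn2-c2ccc(Cl)cc2)cc1`. It differs from compound 1 as follows: 4-chlorophenyl in place of 3-bromophenyl on an aromatic nitrogen. Within the data shown here, the one step on record that resembles this change, a 1.1-fold higher number from compound 2 to compound 3 (0.05 log units; within the scatter), exchanges halogens without a shift beyond the scatter, so the halogen part of the change gives no reason to expect movement. Among the measured compounds shown here, the move of the halogen from the 3-position to the 4-position of the phenyl has no counterpart among the measured compounds, so nothing can be inferred for it. The step from compound 1 to compound 4 is therefore expected to stay within the scatter, a 1.2-fold higher number from compound 1 to compound 4 (0.08 log units; within the scatter). For compound 4 the estimate in this assay is 150000 nM, with a range from 70000 nM to 320000 nM.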

Compound 4, half-maximal inhibitory concentration: 115000 nM
Compound 4: middle estimate off by 1.3-fold (0.12 log units), on the high side, within the range that was stated.
By their numbers in this assay, from the lowest: compounds 4, 1, 2 and 3 (each within the scatter of the next, the first and the last beyond it).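

In this assay the replacement of 3-bromophenyl by 4-chlorophenyl on this aromatic nitrogen (a 1.1-fold lower number from compound 1 to compound 4 (0.03 log units; within the scatter)) leaves the read-out unchanged within the scatter. The earlier compounds shown here showed only one halogen exchanged for another on a different phenyl group, with the rest of the structure held fixed; here the kind of halogen and its place on the phenyl change together, and still no shift beyond the scatter appears, so this site accepts both changes made at once without a visible effect on the number. Nothing available explains this absence of movement.

The two parts of the change remain tied together, so they might each do nothing or might pull in opposite directions, and only a 4-bromophenyl or a 3-chlorophenyl group at this site could tell these cases apart. The compounds shown also leave open whether anything other than a halogen on this phenyl, such as an amine or a carboxylic acid, would hold the number in the same place.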